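A Spirocyclic Replacement on the Amide of Compound 1

A few compounds are considered here, and "the series" means these few. Any claim that something is new, unique, unknown or untested is made for them only; others in the source may bear on it.

Compound 1, `O=C(C1CCC(F)(F)CC1)N1CC(c2nc(-c3cccc(Cl)c3)no2)C1`: in an assay on HEK293 cells for negative allosteric modulation of metabotropic glutamate receptor 5 (Homo sapiens), read by FLIPR (on this read-out lower numbers stand for stronger inhibition and higher numbers for weaker inhibition), compound 1 gives only a limit, > 10000 nM.
Compound 2, `O=C(c1ccccc1F)N1CC[C@H]1c1nc(-c2cccc(F)c2)no1`: in this assay compound 2 gives 920 nM.

Compound 1 stands at the limit of > 10000 nM in this assay, at which 1 of the 2 values shown sits, so no number is known for it, only that the assay did not resolve it. Within the data shown here, compound 2 is the only one of the pair with a measured number. Compound 3, `O=C(C1CCC2(CCC2)CC1)N1CC(c2nc(-c3cccc(Cl)c3)no2)C1`, has not yet been measured. It differs from compound 1 in one place: a group of 9 heavy atoms (9 carbon; one four-membered non-aromatic ring of carbon only, one six-membered non-aromatic ring of carbon only) in place of a group of 8 heavy atoms (6 carbon, 2 fluorine; one six-membered non-aromatic ring of carbon only), on a carbonyl carbon. Among the measured compounds shown here, no measured step exists for this kind of change here, so the direction it takes is open. Since compound 1 is known only as a limit, a change that stays within the usual scatter would leave compound 3 at a limit as well. For compound 3 a value of 12000 nM is expected, within a range of 4000 nM to 40000 nM. The step that the limit leaves unreadable from compound 1 to compound 3 that this estimate implies is expected to be small, with a limit the likeliest outcome.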

Compound 3, half-maximal inhibitory concentration: > 10000 nM
Compound 3 was reported as a limit (the forecaster's own chance of this, stated with the estimate: 70%); the middle value is on the limit's open side.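

No step can be read from compound 1 to compound 3 in this assay, since each is reported only as a limit: the limit of > 10000 nM in this assay, at which 2 of the 3 values shown sit.

The compounds shown leave open whether replacing the 4,4-difluorocyclohexyl group on the carbonyl carbon changes inhibition at all.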